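Turning one ring stereocentre in a sigma-1 ligand

The source may report more compounds than this note shows. Statements on the series, on what has been measured and on what is new or still open speak of the compounds shown alone.

Compound 2 `c1ccc([C@H]2CCC[C@@H](CCN3CCN(c4ccccc4)CC3)C2)cc1` gives the lower of the two numbers recorded in an assay on membranes from brain for displacement of a labelled ligand from Sigma non-opioid intracellular receptor 1 (Cavia porcellus), read by scintillation counting, with a stated time of 120 min (on this read-out higher numbers stand for weaker inhibition and lower numbers for stronger inhibition), at 16 nM. Compound 1 `NCC[C@H]1CCC[C@@H](c2ccccc2)C1` sits well apart; in this assay compound 1 gives 138 nM, a gap beyond the usual scatter. Compound 3 `c1ccc([C@H]2CCC[C@H](CCN3CCN(c4ccccc4)CC3)C2)cc1` is the next case: the two compounds have the same atoms and bonds and differ only in configuration as drawn: 1 of 2 stereo elements differ; a stereocentre at a saturated ring carbon is drawn R in compound 2 and S in compound 3. Going by the values given here, no step of this kind has been measured here, so the size of its effect is open. The author expects a modest move toward a higher number, possibly beyond the scatter, as a 2.2-fold higher number from compound 2 to compound 3 (0.34 log units; beyond the scatter). Compound 3 is estimated at 35 nM, with a range from 8 nM to 150 nM.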

Compound 3, inhibition constant: 13 nM
Compound 3: middle estimate off by 2.7-fold (0.43 log units), on the high side; measured number inside the range.
By their numbers in this assay, from the lowest: compounds 3 and 2 (each within the scatter of the next); then compound 1.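

In this assay the step at this saturated ring carbon is a 1.2-fold lower number from compound 2 to compound 3 (0.09 log units; within the scatter) and so shows that, with this side chain, R and S cannot be told apart at this stereocentre. The earlier compounds shown here gave no reading of configuration, and this pair isolates it: the fact that compounds 2 and 3 differ only in the configuration as drawn.

The compounds shown leave open whether the other stereo element behaves in the same way. They also leave open whether this configuration stays as indifferent with a longer chain or an amide in the side chain.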